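Alkoxy size at the sulfonamide-bearing ring: isopropoxy to methoxy

A few compounds are considered here, and "the series" means these few. Any claim that something is new, unique, unknown or untested is made for them only; others in the source may bear on it.

Compound 1 `Cc1cc2c(cc1NS(=O)(=O)c1ccc(-c3ccc(Cl)cc3)cc1)CCN(C)CC2` carries a methyl on the aromatic carbon of the shared core; in an assay on isolated protein for displacement of a labelled ligand from 5-hydroxytryptamine receptor 6 (Homo sapiens), read by radioligand binding (a lower number here means a stronger inhibitor, a higher number a weaker inhibitor), compound 1 gives 15.9 nM. Compound 2 `CC(C)Oc1cc2c(cc1NS(=O)(=O)c1ccc(-c3ccc(Cl)cc3)cc1)CCN(C)CC2` has isopropoxy at that carbon instead and gives 31.6 nM. For the measured compounds named here, the one step measured so far, a 2.0-fold higher number from compound 1 to compound 2 (0.30 log units; within the scatter), is the only comparison available. Compound 2 thus has the highest of the two numbers, with compound 1 the nearest, a lower number but still within the scatter.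

Compound 3 `COc1cc2c(cc1NS(=O)(=O)c1ccc(-c3ccc(Cl)cc3)cc1)CCN(C)CC2` is not yet measured. From compound 2 the change is methyl in place of isopropyl on an oxygen on an aromatic ring, leaving the oxygen in place. Going by the values given here, only the step from compound 1 to compound 2 bears on this, and it was within the scatter. Methoxy sits between methyl and isopropoxy in size, and neither measured point moved beyond the scatter, so no change beyond the scatter is expected for compound 3; a slightly lower number than compound 2 is considered the more likely direction. The expected step is a 1.6-fold lower number from compound 2 to compound 3 (0.20 log units; within the scatter). Compound 3 is estimated at 20 nM, with a range from 8 nM to 50 nM.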

Compound 3, inhibition constant: 10 nM
The estimate for compound 3 lay 2.0-fold (0.30 log units) above the measured number; measured number inside the range.
By their numbers in this assay, from the lowest: compounds 3, 1 and 2 (each within the scatter of the next, the first and the last beyond it).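

Methyl in place of isopropyl on an oxygen on an aromatic ring gives a 3.2-fold lower number from compound 2 to compound 3 (0.50 log units; beyond the scatter) in this assay, the first step in this short series to pass beyond the scatter, so the alkyl group on that oxygen does register, though only modestly. Methoxy in place of methyl on the aromatic carbon gives a 1.6-fold lower number from compound 1 to compound 3 (0.20 log units; within the scatter), which leaves compound 1 and compound 3 unseparated and shows that the step from compound 2 to compound 3 is visible only when the two alkoxy groups are compared, with compound 1 within the scatter of each. No supporting measurement accompanies these numbers, so the reason for the isopropoxy to methoxy step remains unexplained.

Still open, on these data alone, is whether ethoxy on the same aromatic carbon would track with methoxy or with isopropoxy, and whether a hydroxyl group or an amine there would stay in the same range. Also open, as far as these compounds go, is whether the isopropoxy to methoxy step would persist on the shared core if the chloro group were replaced by a nitrile.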